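A few compounds are considered here, and "the series" means these few. Any claim that something is new, unique, unknown or untested is made for them only; others in the source may bear on it.

Of the compounds shown here, three sharing one core have been tested in a functional assay on SAOS-2 cells (Homo sapiens) for antiproliferative activity, read by MTT assay, with a stated time of 72 h; a higher number here means a weaker inhibitor, a lower number a stronger inhibitor. Compound 1 `CCCCCOC1=C(C(=O)c2ccccc2)C(c2ccc(Br)cc2)N(CCCn2ccnc2)C1=O` gives 9990 nM. Compound 2 `CCCCOC1=C(C(=O)c2ccccc2)C(c2ccc(Br)cc2)N(CCCn2ccnc2)C1=O` gives 11600 nM. Going by the values given here, compound 3 `O=C(C1=C(Nc2ccccc2)C(=O)N(CCCn2ccnc2)C1c1ccc(Br)cc1)c1ccccc1` gives 24400 nM, the highest of the three numbers: the step of a 2.4-fold higher number from compound 1 to compound 3 (0.39 log units; beyond the scatter) and the step of a 2.1-fold higher number from compound 2 to compound 3 (0.32 log units; beyond the scatter) are both modest but lie beyond the scatter, so compound 3 is the weakest inhibitor of the three measured so far.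

Compound 4 `Cc1ccc(NC2=C(C(=O)c3ccccc3)C(c3ccc(Br)cc3)N(CCCn3ccnc3)C2=O)cc1` has not yet been measured. It differs from compound 3 by methyl in place of hydrogen on an aromatic carbon. Among the compounds with values here, none of the measured steps alters an aromatic ring in this way. Within the data shown here, the only step that adds or removes a methyl is a 1.2-fold higher number from compound 1 to compound 2 (0.06 log units; within the scatter), and that one concerns a saturated chain rather than a ring and stays within the scatter, so it offers no clear guide. Among the measured compounds shown here, with no direct precedent, the expectation for compound 4 in this assay is a step of a 1.0-fold lower number from compound 3 to compound 4 (0.01 log units; within the scatter), meaning a number close to that of compound 3, with a wide range to reflect the lack of a matching example. Compound 4 is therefore estimated to give 24000 nM in this assay, between 9000 nM and 60000 nM.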

Compound 4, half-maximal inhibitory concentration: 31900 nM
Beside the measured number, compound 4's estimate is 1.3-fold (0.12 log units) below it, within the range that was stated.
By their numbers in this assay, from the lowest: compounds 1 and 2 (each within the scatter of the next); then compounds 3 and 4 (each within the scatter of the next).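

Placing a methyl on the aromatic ring of the anilino group, to give the (4-methylphenyl)amino group, produces a 1.3-fold higher number from compound 3 to compound 4 (0.12 log units; within the scatter) in this assay, so this change, at a ring carbon para to a large group, gives no clear shift in the number. The gap to the compounds with an oxygen-linked chain remains, with a 2.8-fold higher number from compound 2 to compound 4 (0.44 log units; beyond the scatter) and a 3.2-fold higher number from compound 1 to compound 4 (0.50 log units; beyond the scatter), both modest but beyond the scatter, so compound 4 joins compound 3 in having a higher number than compound 1 and compound 2, and neither of the two goes against this within these four compounds. Nothing measured here accounts for the small methyl step or for the gap between the nitrogen-linked and oxygen-linked groups.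

On these data alone, whether a larger or different group on that same ring carbon, such as methoxy, chlorine or a carboxylic acid, would move the number beyond the scatter remains open. Also open, as far as these compounds go, is whether a butylamino group, which keeps the nitrogen link but carries a saturated chain instead of the aromatic ring, would sit with compound 3 and compound 4 or with compound 1 and compound 2.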